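4-Methoxyphenyl to octyl: cytotoxicity notes on the series

A few compounds are considered here, and "the series" means these few. Any claim that something is new, unique, unknown or untested is made for them only; others in the source may bear on it.

Compound 1 `COc1ccc(/C=N/NC(=O)c2cnc3c(C(F)(F)F)cccc3c2N[C@@H](CSc2ccccc2)CC(=O)N(C)C)cc1` has no result in an ADME assay on Vero cells (Chlorocebus sabaeus) for cytotoxicity, read by MTT assay, with a stated time of 72 h (on this read-out lower numbers stand for stronger inhibition and higher numbers for weaker inhibition), where compound 1 is recorded as "not determined" (no result reported). Compound 2 `CN(C)C(=O)C[C@H](CSc1ccccc1)Nc1c(C(=O)N/N=C/c2cccnc2)cnc2c(C(F)(F)F)cccc12` gives > 62.5 ug/mL in this assay, a limit of the assay and not a number. Among the compounds with values here, compound 1 therefore stands without any number of its own, and the one further value is a limit (the limit of > 62.5 ug/mL in this assay, at which 1 of the 2 values shown sits). Compound 3 `CCCCCCCC/C=N/NC(=O)c1cnc2c(C(F)(F)F)cccc2c1N[C@@H](CSc1ccccc1)CC(=O)N(C)C` differs from compound 1 by octyl in place of 4-methoxyphenyl on a carbon with a double bond to nitrogen. Within the data shown here, no measured step accompanies this change; with octyl in place of 4-methoxyphenyl, no shift beyond the usual scatter is expected in this assay, in either direction. Compound 3 is expected to give about 70 ug/mL in this assay, within a range from 30 ug/mL to 160 ug/mL, most probably reported only as a limit.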

Compound 3, half-maximal inhibitory concentration: > 62.5 ug/mL
Compound 3 was reported as a limit (the forecaster's own chance of this, stated with the estimate: 70%); the middle value does not contradict the limit.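

Compound 2 and compound 3 are both recorded as limits and not as numbers, so no step can be read between them: the limit of > 62.5 ug/mL in this assay, at which 2 of the 3 values shown sit.

From the compounds shown here alone, whether octyl and pyridin-3-yl on a carbon with a double bond to nitrogen differ at all in this assay stays open.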